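Adding a Second Fluorine Near the Sulfonylmethyl Group

The source may hold more compounds than are shown below. What is called first, only, known or untested is meant among the compounds shown, and "the series" means these compounds.

Compound 1 `C[C@@H](O[C@H]1CC[C@]2(CC1)COC(C)(C)C2)c1nc(-c2ccc(CS(C)(=O)=O)c(F)c2)no1` reaches 106% in a functional assay on HEK293 cells for agonist activity at Glucose-dependent insulinotropic receptor (Homo sapiens), read by cAMP accumulation, with a stated time of 30 min (a higher number here means a larger maximal response, a lower number a smaller maximal response), which places it second highest of the three measured compounds: compound 3 `C[C@@H](O[C@H]1CC[C@]2(CC1)COC(C)(C)C2)c1nc(-c2cc(F)c(CS(C)(=O)=O)cc2F)no1` gives 118%, and compound 2 `C[C@@H](O[C@H]1CC[C@]2(CC1)COC(C)(C)C2)c1nc(-c2ccc(CS(C)(=O)=O)c(F)c2F)no1` gives 77%. The step from compound 1 to compound 4 `C[C@@H](O[C@H]1CC[C@]2(CC1)COC(C)(C)C2)c1nc(-c2cc(F)c(CS(C)(=O)=O)c(F)c2)no1` consists of fluoro in place of hydrogen on an aromatic carbon. Among the compounds with values here, two measured steps bear on this change, both also a fluoro in place of hydrogen on an aromatic carbon of the same ring: a number 29 percentage points lower from compound 1 to compound 2 (beyond the scatter) and a number 12 percentage points higher from compound 1 to compound 3 (beyond the scatter). These two steps point in opposite directions, and neither places the new fluoro ortho to the (methylsulfonyl)methyl group as the change to compound 4 does, so they give no single direction to carry over. Compound 4 is therefore expected to stay roughly where compound 1 stands, with an estimated step of a number 6 percentage points lower from compound 1 to compound 4 (within the scatter) that may fall either side of the scatter. The estimate for compound 4 in this assay is 100%, with a range from 75% to 125%.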

Compound 4, largest response reached (reported as percent of maximum), in percent of the reference or control that the assay uses: 109%
Estimate against measurement, compound 4: 9 percentage points below; low and high end bracket the measured number.
By their numbers in this assay, from the lowest: compound 2; then compounds 1, 4 and 3 (each within the scatter of the next, the first and the last beyond it).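

In this assay, a fluoro ortho to the (methylsulfonyl)methyl group and meta to a fluoro group leaves the maximal response unchanged within the scatter, with a number 3 percentage points higher from compound 1 to compound 4 (within the scatter). The other two fluoro additions on this ring both moved the response beyond the scatter, in opposite directions (a number 29 percentage points lower from compound 1 to compound 2 (beyond the scatter)) and (a number 12 percentage points higher from compound 1 to compound 3 (beyond the scatter)), so this position is the one of the three shown where the change cannot be told from the scatter. Nothing measured here explains why the three positions differ.

The compounds shown leave open whether chloro, methoxy or nitrile at this position would also leave the response unchanged. They also leave open whether the same holds with an amine in place of the (methylsulfonyl)methyl group.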